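The compounds below may be only part of what the source reports. "The series", "measured", "known", "first", "only" and "open" are said of these compounds alone.

In a functional assay (trachea) for inhibition, with Cavia porcellus as the target (on this read-out higher numbers stand for weaker inhibition and lower numbers for stronger inhibition), compound 1 `CC1(C)c2ccc([N+](=O)[O-])cc2[C@@H](N2CCCCC2=O)[C@H]1O` gives 350 nM and compound 2 `CC1(C)c2ccc(C#N)cc2[C@@H](N2CCCCC2=O)[C@@H]1O` gives 270 nM, two values within the usual scatter of each other. Compound 3 `CCc1ccc2c(c1)C(C)(C)[C@@H](O)[C@@H]2N1CCCCC1=O` yields no number, only a limit of the assay: > 20000 nM. That limit leaves compound 3 on the weak side of compound 1 and compound 2.

Compound 4 `CC1(C)c2cc(C(F)(F)F)ccc2[C@@H](N2CCCCC2=O)[C@@H]1O` changes one group of compound 3, with trifluoromethyl in place of ethyl on an aromatic carbon. Going by the values given here, no measured pair isolates such a change, so any forecast is indirect. Among the compounds with values here, compound 2, at 270 nM, shows that this family can give real inhibition, yet its ring group sits on a different ring carbon from the one shared by compound 3 and compound 4. Some gain in inhibition is therefore expected, but with much uncertainty, and the estimated step runs an at least 6.6-fold lower number from compound 3 to compound 4 (0.82 log units; beyond the scatter). For compound 4 the expected value is 3000 nM, with an estimated range of 500 nM to 15000 nM.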

Compound 4, half-maximal inhibitory concentration: > 20000 nM
Compound 4: a limit, no number; the forecaster's own chance of this, stated with the estimate: 30%; middle value at least 6.6-fold (0.82 log units) from the limit.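

Going by these compounds alone, compound 3 and compound 4 each give only a limit of the assay, not a number, so no step between them can be read: the limit of > 20000 nM in this assay, at which 2 of the 4 values shown sit. From the compounds shown here alone, what trifluoromethyl in place of ethyl on an aromatic carbon does to inhibition therefore stays open.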